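Swapping the aryl arm of a pyrazole acid for a nitrobenzyl

The compounds below may be only part of what the source reports. "The series", "measured", "known", "first", "only" and "open" are said of these compounds alone.

Of the compounds shown here, two of the shared core have been measured so far. Compound 1 `Cc1nn(-c2nc(-c3ccc(Cl)c(Cl)c3)c(SC(C)C)s2)c(C(=O)O)c1-c1cccc(C(F)(F)F)c1` gives 22000 nM in a functional assay on BJAB cells (Homo sapiens) for antiproliferative activity, with a stated time of 4 days (on this read-out higher numbers stand for an effect only at larger amounts of compound and lower numbers for an effect already at smaller amounts), and stands as the lower of the two numbers. Compound 2 `CCSc1sc(-n2nc(C)c(Cc3ccccc3[N+](=O)[O-])c2C(=O)OC)nc1-c1ccc(Cl)c(Cl)c1`, which carries a 2-nitrobenzyl together with an ethylthio group and a methyl ester, gives 106000 nM in this assay, a number beyond the scatter above that of compound 1. Compound 3 `Cc1nn(-c2nc(-c3ccc(Cl)c(Cl)c3)c(SC(C)C)s2)c(C(=O)O)c1Cc1ccccc1[N+](=O)[O-]` keeps the isopropylthio group and the free carboxy group of compound 1 and differs from it in one place: 2-nitrobenzyl in place of 3-(trifluoromethyl)phenyl on an aromatic carbon. Among the compounds with values here, no measured pair shows this change on its own. Since compound 2 with its 2-nitrobenzyl sits well above compound 1, the change is expected to weaken activity, by a 2.3-fold higher number from compound 1 to compound 3 (0.36 log units; beyond the scatter), but less than the full gap to compound 2, which also differs in two other places. Compound 3 is therefore estimated at 50000 nM, with a range from 15000 nM to 160000 nM.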

Compound 3, half-maximal effective concentration: 20000 nM
Estimate against measurement, compound 3: 2.5-fold (0.40 log units) above, and the stated range covers the measured number.
By their numbers in this assay, from the lowest: compounds 3 and 1 (each within the scatter of the next); then compound 2.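

In this assay, within the data shown here, putting 2-nitrobenzyl in place of 3-(trifluoromethyl)phenyl on this aromatic carbon gives a 1.1-fold lower number from compound 1 to compound 3 (0.04 log units; within the scatter), the first reading of this change on its own. With the isopropylthio group and the free carboxy group held in place, the position thus takes these two different aryl-bearing arms without a difference beyond the scatter, and the 2-nitrobenzyl alone brings no loss on this core. No measurement at hand explains why the two arms read alike.

On these data alone, both arms carry a six-membered aromatic ring of carbon, so it remains open how an amine, a short alkyl chain or a plain benzyl would read at this carbon. Also open, as far as these compounds go, is whether the same holds when an amide replaces the carboxy group.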